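Benzofuran regiochemistry at the sulfur-linked bicycle

The source may hold more compounds than are shown below. What is called first, only, known or untested is meant among the compounds shown, and "the series" means these compounds.

Measured so far:
compound 1 `Nc1ncnc2c1nc(Sc1cc3c(cc1Br)CCO3)n2CCC1CCN(C=O)CC1` — 1800 nM
compound 2 `Nc1ncnc2c1nc(Sc1cc3c(cc1Br)OCC3)n2CCC1CCN(C=O)CC1` — 86000 nM
compound 3 `Nc1ncnc2c1nc(Sc1cc3occc3cc1Br)n2CCC1CCN(C=O)CC1` — 1100 nM

All three share the same core and differ only in the brominated bicyclic group on the sulfur. In a functional assay on NCI/ADR-RES cells (Homo sapiens) for inhibition, read by luminescence, with a stated time of 72 h (on this read-out higher numbers stand for weaker inhibition and lower numbers for stronger inhibition), compound 3 gives the lowest number of the three; its nearest neighbour is compound 1, where a 1.6-fold lower number from compound 1 to compound 3 (0.21 log units; within the scatter), and its furthest is compound 2, where a 78-fold lower number from compound 2 to compound 3 (1.89 log units; beyond the scatter).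

Compound 4 `Nc1ncnc2c1nc(Sc1cc3ccoc3cc1Br)n2CCC1CCN(C=O)CC1` is the next member. It differs from compound 3 in this way: 6-bromo-1-benzofuran-5-yl in place of 5-bromo-1-benzofuran-6-yl on a sulfur.

The step that bears on this is the one between the two non-aromatic bicycles, where the attachment to sulfur and the placement of the oxygen are exchanged in the same manner: a 48-fold higher number from compound 1 to compound 2 (1.68 log units; beyond the scatter), a large effect. The step of a 1.6-fold lower number from compound 1 to compound 3 (0.21 log units; within the scatter) shows that making the five-membered ring aromatic changes little, so the rearrangement within the aromatic pair is expected to behave like the rearrangement within the non-aromatic pair. Going by the values given here, a large step to a higher number is therefore expected, a 27-fold higher number from compound 3 to compound 4 (1.44 log units; beyond the scatter), though with only one precedent the size is uncertain.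

Compound 4 is thus estimated at 30000 nM, with a range of 7000 nM to 120000 nM.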

Compound 4, half-maximal inhibitory concentration: 7900 nM
Compound 4: middle estimate off by 3.8-fold (0.58 log units), on the high side, and the stated range covers the measured number.
By their numbers in this assay, from the lowest: compounds 3 and 1 (each within the scatter of the next); then compound 4; then compound 2.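

In this assay the attachment of the bicycle to the sulfur also matters in the fully aromatic pair: a 7.2-fold higher number from compound 3 to compound 4 (0.86 log units; beyond the scatter), so 6-bromo-1-benzofuran-5-yl is a poorer group here than 5-bromo-1-benzofuran-6-yl, yet this modest step is not the large one seen in the non-aromatic pair, where a 48-fold higher number from compound 1 to compound 2 (1.68 log units; beyond the scatter). Aromatising the five-membered ring therefore has an effect that depends on the arrangement: an 11-fold lower number from compound 2 to compound 4 (1.04 log units; beyond the scatter), a large step beyond the scatter, whereas a 1.6-fold lower number from compound 1 to compound 3 (0.21 log units; within the scatter) stays within the scatter. The comparison with the non-aromatic group of the better arrangement adds that a 4.4-fold higher number from compound 1 to compound 4 (0.64 log units; beyond the scatter), so the aromatic ring does not fully restore the level of compound 1 in the arrangement of compound 4.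

Still open, as far as these compounds go, is whether this dependence on arrangement survives when the bromine gives way to chlorine, methoxy or a nitrile on these bicycles. Nothing on hand accounts for the smaller step within the benzofuran pair.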